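Fluoro Substitution Carried Over to a Rearranged Core

The compounds below may be only part of what the source reports. "The series", "measured", "known", "first", "only" and "open" are said of these compounds alone.

Compound 1 `COc1ccccc1S(=O)(=O)/C=C/c1ccccn1` was examined in an assay on U2OS cells for activation of nuclear factor erythroid 2-related factor 2 (Homo sapiens), read by chemiluminescence, with a stated time of 6 h (on this read-out lower numbers stand for an effect already at smaller amounts and higher numbers for an effect only at larger amounts of compound), where compound 1 gives 9070 nM. Compound 2 `COc1ccccc1S(=O)(=O)/C=C/c1ncccc1F` differs from compound 1 by a single change, (fluoro in place of hydrogen on an aromatic carbon), and in this assay compound 2 gives 877 nM, so that the step of a 10-fold lower number from compound 1 to compound 2 (1.01 log units; beyond the scatter) is a large one. Compound 3 `COc1cccc(S(=O)(=O)/C=C/c2ccccn2)c1` is built from the same atoms joined differently; the difference between the two cores is not broken down here. In this assay compound 3 gives 2170 nM. Compound 4 `COc1cccc(S(=O)(=O)/C=C/c2ncccc2F)c1` has not yet been measured; it differs from compound 3 by fluoro in place of hydrogen on an aromatic carbon, the same change made once before, at a place described in the same words. Going by the values given here, the expected step is a 6.8-fold lower number from compound 3 to compound 4 (0.83 log units; beyond the scatter), kept somewhat smaller than the earlier one since it rests on the single step of a 10-fold lower number from compound 1 to compound 2 (1.01 log units; beyond the scatter). Compound 4 is therefore expected to give 320 nM, likely between 120 nM and 850 nM.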

Compound 4, half-maximal effective concentration: 444 nM
Compound 4: middle estimate off by 1.4-fold (0.14 log units), on the low side; the measured number falls inside the stated range.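

In this assay, fluoro in place of hydrogen on an aromatic carbon lowers the number on the rearranged core as well, with a 4.9-fold lower number from compound 3 to compound 4 (0.69 log units; beyond the scatter) and thus a step in the same direction as on the core of compound 1. The two steps cannot be told apart in size, since the gap between them lies within the scatter: the same change on two cores in this assay, a 10-fold lower number (1.01 log units; beyond the scatter) from compound 1 to compound 2 and a 4.9-fold lower number (0.69 log units; beyond the scatter) from compound 3 to compound 4, 2.1-fold (0.33 log units) apart, within the scatter of two such steps. Going by these compounds alone, this rests on only two pairs of compounds, so it shows that the change carried over between these two cores, not that it would carry over to any other core, and it does not show why the number falls.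

The compounds shown leave open whether another group at this place, such as chloro, methyl or an amine, would lower the number as far. They also leave open what fluoro would do elsewhere on this ring.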